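This account rests on a few compounds, and the source may have more. Where it says the series, first, only, none or still open, it means among the compounds named here.

In a functional assay on PC-3 cells (Homo sapiens) for cytotoxicity, read by MTT assay, with a stated time of 72 h (a lower number here means a stronger inhibitor, a higher number a weaker inhibitor), compound 1 `CNC(=O)c1cc(Oc2ccc(NC(=O)c3cc(-c4ccc(C)cc4)ncn3)cc2)ccn1` gives > 100000 nM, which is a limit and not a number. Within the data shown here, compound 2 `CCc1ccc(-c2cc(C(=O)Nc3ccc(Oc4ccnc(C(=O)NC)c4)cc3)ncn2)cc1` gives 29300 nM, the only true number so far. Compound 3 `CNC(=O)c1cc(Oc2ccc(NC(=O)c3cc(-c4ccc(Cl)cc4)ncn3)cc2)ccn1` carries chloro in place of ethyl on an aromatic carbon. One measured step changes this same group: an at least 3.4-fold lower number from compound 1 to compound 2 (0.53 log units; beyond the scatter), and it rests on (the limit of > 100000 nM in this assay, at which 1 of the 2 values shown sits). Among the measured compounds shown here, with only that modest step as a guide, a similarly modest move toward a higher number is expected. The expected step is a 1.7-fold higher number from compound 2 to compound 3 (0.23 log units; within the scatter). For compound 3, the estimate is 50000 nM, with a range from 15000 nM to 100000 nM.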

Compound 3, half-maximal inhibitory concentration: > 100000 nM
Compound 3 gave a limit, no number; the forecaster's own chance of this, stated with the estimate: 35%; at least 2.0-fold (0.30 log units) between middle value and limit.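

Putting 4-chlorophenyl in place of 4-ethylphenyl gives an at least 3.4-fold higher number from compound 2 to compound 3 (0.53 log units; beyond the scatter), so ethyl is now set apart from two smaller groups at this position, chloro as well as methyl. For compound 3, > 100000 nM is a limit and not a number. The step between the two limit compounds cannot be read, and much of this small set rests at that ceiling: the limit of > 100000 nM in this assay, at which 2 of the 3 values shown sit.

Going by these compounds, whether a propyl chain or an amine in this place would give a lower number than compound 2 stays open. On these data alone, how far compound 1 and compound 3 truly lie beyond the limit also stays open.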